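Chain extension on the thioether of the shared core

The source may report more compounds than this note shows. Statements on the series, on what has been measured and on what is new or still open speak of the compounds shown alone.

Compound 1 `Nc1nc(=O)ccn1[C@@H]1O[C@H](COP(=O)(O)OP(=O)(O)O)[C@@H](O)[C@H]1O` carries an amino group on the aromatic carbon of the shared core; in an in vitro functional assay on 1321-N1 cells for agonist activity at P2Y purinoceptor 4 (Homo sapiens), read by scintillation proximity assay and inositol phosphate accumulation (on this read-out higher numbers stand for an effect only at larger amounts of compound and lower numbers for an effect already at smaller amounts), compound 1 reaches only >= 100000 nM, which is a limit of the assay and not a number. Compound 3 `CNc1nc(=O)ccn1[C@@H]1O[C@H](COP(=O)(O)O)[C@@H](O)[C@H]1O` in this assay likewise stops at > 100000 nM, again a limit and not a number. Among the measured compounds shown here, compound 2 `CSc1nc(=O)ccn1[C@@H]1O[C@H](COP(=O)(O)OP(=O)(O)O)[C@@H](O)[C@H]1O` gives 1520 nM in this assay, the only actual number among the three. For the measured compounds named here, the single measured step, an at least 65-fold lower number from compound 1 to compound 2 (1.81 log units; beyond the scatter), is the one that turns a limit into a number. Compound 4 `CCCSc1nc(=O)ccn1[C@@H]1O[C@H](COP(=O)(O)OP(=O)(O)O)[C@@H](O)[C@H]1O` differs from compound 2 by ethyl in place of hydrogen on a saturated chain carbon bound to a sulfur. Going by the values given here, no measured step touches the length of the chain on the sulfur; the step from compound 1 to compound 2 exchanges the group on the aromatic carbon itself and so does not bear on a chain extension. Among the compounds with values here, with no comparable step, the expectation for compound 4 in this assay is a change no larger than the scatter, in either direction: a 1.0-fold lower number from compound 2 to compound 4 (0.01 log units; within the scatter). Compound 4 is therefore estimated at 1500 nM in this assay, within 500 nM to 5000 nM.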

Compound 4, half-maximal effective concentration: 4900 nM
For compound 4 the middle estimate is 3.3-fold (0.51 log units) below the measured one; low and high end bracket the measured number.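

The chain on the sulfur proves not to be a neutral place in the series: in this assay there is a 3.2-fold higher number from compound 2 to compound 4 (0.51 log units; beyond the scatter), a modest loss on going from methylsulfanyl to propylsulfanyl. The advantage of a thioether over the amino group nonetheless survives the longer chain, with an at least 20-fold lower number from compound 1 to compound 4 (1.30 log units; beyond the scatter). That step remains a bound, since compound 1 stands at a limit of the assay and not at a number: the limit of >= 100000 nM in this assay, at which 1 of the 4 values shown sits.

From the compounds shown here alone, two chain lengths give a direction but not a trend, so it remains open whether ethylsulfanyl or butylsulfanyl would fall on a smooth line with methylsulfanyl and propylsulfanyl. Going by these compounds, it is equally open how a branched chain such as isopropyl, or a benzyl group, on the sulfur would read.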